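Aryl groups on the sulfonamide nitrogen: working notes

A few compounds are considered here, and "the series" means these few. Any claim that something is new, unique, unknown or untested is made for them only; others in the source may bear on it.

Measured in a functional assay on K562 cells (Homo sapiens) for inhibition, read by CCK-8 assay, with a stated time of 72 h; on this read-out lower numbers stand for stronger inhibition and higher numbers for weaker inhibition:
- compound 1 `CC(C)(C)c1ccc(NS(=O)(=O)c2cccc(CCCCCCNC(=O)/C=C/c3cccnc3)c2)cc1`: 24.7 nM
- compound 2 `O=C(/C=C/c1cccnc1)NCCCCCCc1cccc(S(=O)(=O)Nc2ccc(F)c(Cl)c2)c1`: 5.31 nM

Compound 2 holds the lower of the two numbers. Compound 3 `O=C(/C=C/c1cccnc1)NCCCCCCc1cccc(S(=O)(=O)Nc2ccc(C(F)(F)F)cc2)c1` is not yet measured. It differs from compound 2 as follows: 4-(trifluoromethyl)phenyl in place of 3-chloro-4-fluorophenyl on a sulfonamide nitrogen. Among the measured compounds shown here, one measured step bears on this place: a 4.7-fold lower number from compound 1 to compound 2 (0.67 log units; beyond the scatter), a modest step beyond the scatter. For the measured compounds named here, the 4-(trifluoromethyl)phenyl group itself has no measured precedent, so only a small rise is expected, possibly within the scatter. The expected change is a 1.7-fold higher number from compound 2 to compound 3 (0.23 log units; within the scatter). For compound 3 the estimated value is 9 nM, with an expected range of 3.5 nM to 25 nM.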

Compound 3, half-maximal inhibitory concentration: 44.9 nM
The estimate for compound 3 lay 5.0-fold (0.70 log units) below the measured number; measured number outside the range, above it.
By their numbers in this assay, from the lowest: compound 2; then compounds 1 and 3 (each within the scatter of the next).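

In this assay the aryl group on the sulfonamide nitrogen matters more than the earlier pair showed: an 8.5-fold higher number from compound 2 to compound 3 (0.93 log units; beyond the scatter). Trifluoromethyl in place of tert-butyl on an aromatic carbon gives a 1.8-fold higher number from compound 1 to compound 3 (0.26 log units; within the scatter), so among these three compounds only the 3-chloro-4-fluorophenyl group of compound 2 stands apart. No measurement at hand accounts for this difference.

Among the compounds shown here, still open is whether the chlorine, the fluorine or only the pair of them sets compound 2 apart. Also open, as far as these compounds go, is how an aryl group carrying a methoxy group or a carboxylic acid would compare.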